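Closing a Branched Side Chain into a Small Ring

The source may report more compounds than this note shows. Statements on the series, on what has been measured and on what is new or still open speak of the compounds shown alone.

Measured compounds:
- compound 1, `COc1cc(Cc2nc3c(N)ncnc3n2CCCCO)cc(OC)c1OC`: 76900000 nM
- compound 2, `COc1cc(Cc2nc3c(N)ncnc3n2CC(C)CCCO)cc(OC)c1OC`: 8770000 nM
- compound 3, `CC[C@H](C)Cn1c(Cc2cc(OC)c(OC)c(OC)c2)nc2c(N)nc(F)nc21`: 66700000 nM

In a functional assay on MCF7 cells (Homo sapiens) for cytotoxicity (a higher number here means that more compound is needed for the effect, a lower number that less compound is needed), compound 3 stands second highest of the three numbers. Its nearest neighbour is compound 1, whose number is higher only within the scatter, so the two cannot be told apart. Among the measured compounds shown here, compound 2 sits clearly lower, and the one measured step, an 8.8-fold lower number from compound 1 to compound 2 (0.94 log units; beyond the scatter), shows how much a change on the saturated chain carbon bound to the aromatic nitrogen can move this assay.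

Compound 4, `COc1cc(Cc2nc3c(N)nc(F)nc3n2CC2CCC2)cc(OC)c1OC`, keeps the core and the fluorine of compound 3 and differs by cyclobutyl in place of sec-butyl on a saturated chain carbon bound to an aromatic nitrogen. For the measured compounds named here, no measured pair shows this kind of change, a branched chain closed into a ring of the same size; the step from compound 1 to compound 2 concerns a hydroxyl-bearing chain and bears on it only loosely. Because of an 8.8-fold lower number from compound 1 to compound 2 (0.94 log units; beyond the scatter) a shift of that order is the most one would expect, and a smaller one is more likely. The estimate for compound 4 is 60000000 nM, within 20000000 nM to 200000000 nM, a step of a 1.1-fold lower number from compound 3 to compound 4 (0.05 log units; within the scatter) expected to stay within the scatter.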

Compound 4, half-maximal effective concentration: 109000000 nM
For compound 4 the middle estimate is 1.8-fold (0.26 log units) below the measured one; measured number inside the range.
By their numbers in this assay, from the lowest: compound 2; then compounds 3, 1 and 4 (each within the scatter of the next).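

In this assay, closing sec-butyl into cyclobutyl on a saturated chain carbon bound to an aromatic nitrogen gives a 1.6-fold higher number from compound 3 to compound 4 (0.21 log units; within the scatter). This change adds a ring and removes the defined stereocentre while keeping the same number of carbons, yet it produces no shift that can be told from ordinary scatter, unlike the earlier chain change, an 8.8-fold lower number from compound 1 to compound 2 (0.94 log units; beyond the scatter). Nothing measured explains this outcome.

Compound 2 differs from compound 3 and compound 4 in more than one place, so these compounds do not show which of its features goes with its lower number. As far as these compounds go, whether a cyclopentyl ring, a longer chain or an amine at this position would move the number beyond the scatter also remains open.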